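Compound 3 to compound 4, at a reporting limit

The compounds below may be only part of what the source reports. "The series", "measured", "known", "first", "only" and "open" are said of these compounds alone.

Values in a physicochemical assay for solubility, using the shake flask method, in simulated intestinal fluid, measured as kinetic solubility, with a stated time of 2 h, at 25 degrees C, at pH 6.5; a higher number here means a more soluble compound, a lower number a less soluble compound:
- Compound 1 `Cc1noc(-c2nc(C)c3c(c2N)C(=O)N(CC2CCNCC2)C3=O)n1` gives 160000 nM
- Compound 2 `Cc1noc(-c2nc(C)c3c(c2N)C(=O)N(Cc2ccc(Cl)cc2)C3=O)n1` gives < 5000 nM (a limit)
- Compound 3 `Cc1noc(-c2nc(C)c3c(c2N)C(=O)N(Cc2ccc(OC(F)F)cc2)C3=O)n1` gives < 5000 nM (a limit)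

In this assay compound 3 stands at < 5000 nM, which is a limit and not a number, and this is the limit of < 5000 nM in this assay, at which 2 of the 3 values shown sit. Compound 4 `Cc1noc(-c2nc(C)c3c(c2N)C(=O)N(Cc2ccc(Cl)cn2)C3=O)n1` carries 5-chloropyridin-2-yl in place of 4-(difluoromethoxy)phenyl on a saturated chain carbon bound to an amide-type nitrogen in a ring. The closest evidence is a step that the two limits leave unreadable from compound 2 to compound 3, which gives no size. The large steps of an at least 32-fold lower number from compound 1 to compound 2 (1.50 log units; beyond the scatter) and an at least 32-fold lower number from compound 1 to compound 3 (1.50 log units; beyond the scatter) both replaced piperidin-4-yl, which compound 4 also lacks. No step beyond the scatter is therefore expected, and another limit is likely. The expected change is a number no lower from compound 3 to compound 4 (the limit leaves the size open). For compound 4 the estimated value is 5000 nM, with an expected range from 1500 nM to 15000 nM.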

Compound 4, solubility: < 5000 nM
Compound 4 was reported as a limit (the forecaster's own chance of this, stated with the estimate: 65%); the middle value lies on the limit itself.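

In this assay compound 4 gives < 5000 nM, which is a limit and not a number. With 5-chloropyridin-2-yl, a ring holding a hetero atom, in this place, the step away from piperidin-4-yl remains large: an at least 32-fold lower number from compound 1 to compound 4 (1.50 log units; beyond the scatter). The steps to compound 4 from compound 2 and compound 3 cannot be read, and one limit now holds most of the series: the limit of < 5000 nM in this assay, at which 3 of the 4 values shown sit.

Going by these compounds, how far apart compound 2, compound 3 and compound 4 truly lie stays open. So does whether a morpholine, a dimethylamino chain or a carboxylic acid in this place would give a value clear of the limit.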